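A few compounds are considered here, and "the series" means these few. Any claim that something is new, unique, unknown or untested is made for them only; others in the source may bear on it.

Four compounds built from the same atoms are joined in two different ways. Compound 1 `O=c1cc(CSC(=S)N2CCCCC2)oc2cc(Cl)ccc12` and compound 2 `O=c1cc(CSC(=S)N2CCCC2)oc2cc(Cl)ccc12` share one core, while compound 3 `O=c1c(CSC(=S)N2CCCCC2)coc2cc(Cl)ccc12` and compound 4 `O=c1c(CSC(=S)N2CCCC2)coc2cc(Cl)ccc12` share another; the difference between the two cores is not broken down here. In a functional assay on HeLa cells (Homo sapiens) for antiproliferative activity, read by MTT assay, with a stated time of 72 h (a lower number here means a stronger inhibitor, a higher number a weaker inhibitor), compound 1 gives > 25000 nM, which is a limit of the assay rather than a number. In this assay compound 2 gives > 40000 nM, also a limit. Compound 2 differs from compound 1 by pyrrolidin-1-yl in place of piperidin-1-yl on a thiocarbonyl carbon, and with both values sitting at limits, the limit of > 25000 nM in this assay, at which 1 of the 3 values shown sits, and (the limit of > 40000 nM in this assay, at which 1 of the 3 values shown sits), the step that the two limits leave unreadable from compound 1 to compound 2 cannot be read. In this assay, for the measured compounds named here, compound 3 gives 440 nM, the only plain number so far. Compound 4 carries the same change, (pyrrolidin-1-yl in place of piperidin-1-yl on a thiocarbonyl carbon), on the core of compound 3. The pair of compound 1 and compound 2 offers no readable size for this change, so the expectation rests on compound 3 and its value of 440 nM together with the usual scatter. From compound 3 the expected step is a 1.4-fold higher number from compound 3 to compound 4 (0.13 log units; within the scatter). Compound 4 is therefore estimated at 600 nM, with a likely range from 200 nM to 2500 nM.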

Compound 4, half-maximal inhibitory concentration: 1300 nM
Compound 4: middle estimate off by 2.2-fold (0.34 log units), on the low side; the measured number falls inside the stated range.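

In this assay, putting pyrrolidin-1-yl in place of piperidin-1-yl on a thiocarbonyl carbon of the core of compound 3 gives a 3.0-fold higher number from compound 3 to compound 4 (0.47 log units; beyond the scatter), so on this core the five-membered ring goes with a weaker inhibitor. On the other core, compound 1 gives a limit of the assay rather than a number: the limit of > 25000 nM in this assay, at which 1 of the 4 values shown sits. Compound 2 also gives a limit, so the size of the change on that core cannot be read, and this single step does not show whether the change carries from one core to the other: the limit of > 40000 nM in this assay, at which 1 of the 4 values shown sits.

For the compounds shown here, only two groups appear on the thiocarbonyl carbon, so one readable step is all there is to go on for this position. As far as these compounds go, how an open-chain amine such as diethylamino, or a ring with an added oxygen atom such as morpholin-4-yl, would behave there on the core of compound 3 remains open.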